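Replacing the acyl amino group in a cytotoxic tricyclic series

The source may report more compounds than this note shows. Statements on the series, on what has been measured and on what is new or still open speak of the compounds shown alone.

Measured compounds:
- Compound 1, `CC(Cl)CC(=O)NC1=C(C#N)C(c2ccc(Cl)cc2Cl)C2=C(CCCC2=O)N1c1ccc(S(N)(=O)=O)cc1`: 60%
- Compound 2, `N#CC1=C(NC(=O)C2CC2)N(c2ccc(S(N)(=O)=O)cc2)C2=C(C(=O)CCC2)C1c1ccc(Cl)cc1Cl`: 60%
- Compound 3, `N#CC1=C(NC(=O)/C=C/c2ccccc2)N(c2ccc(S(N)(=O)=O)cc2)C2=C(C(=O)CCC2)C1c1ccc(Cl)cc1Cl`: 45%

In a functional assay on Ehrlich cells (Mus musculus) for cytotoxicity, read by trypan blue exclusion, with a stated time of 2 h, tested at 100 ug/mL (on this read-out higher numbers stand for a stronger effect at the one concentration tested and lower numbers for a weaker effect), compound 3 gives 45%, the lowest of the three numbers. Its steps to the other two compounds are each beyond the scatter: a number 15 percentage points lower from compound 1 to compound 3 (beyond the scatter) and a number 15 percentage points lower from compound 2 to compound 3 (beyond the scatter). Both of those steps brought the 2-phenylethenyl group onto the carbonyl carbon, and in each case the number fell by a modest amount.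

Compound 4, `CCO/C=N/C1=C(C#N)C(c2ccc(Cl)cc2Cl)C2=C(CCCC2=O)N1c1ccc(S(N)(=O)=O)cc1`, differs from compound 3 as follows: a group of 5 heavy atoms (3 carbon, 1 nitrogen, 1 oxygen; no ring) in place of a group of 11 heavy atoms (9 carbon, 1 nitrogen, 1 oxygen; one six-membered aromatic ring of carbon only), on a double-bonded ring carbon

Among the measured compounds shown here, no measured step removes the ((2-phenylethenyl)carbonyl)amino group altogether, so the two steps above bear on this change only loosely. They do show that the number is higher when the 2-phenylethenyl group is absent, which is also true of compound 4. A return toward the numbers of compound 1 and compound 2 is therefore expected, though the entering group is unlike anything measured, so the uncertainty is wide.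

Compound 4 is estimated to give 55% in this assay, within 35% to 75%, which corresponds to an expected step of a number 10 percentage points higher from compound 3 to compound 4 (within the scatter).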

Compound 4, a percentage reported as activity, at one concentration (the size of the read-out at that concentration, not a potency): 40%
Compound 4: the middle estimate sits 15 percentage points above what was measured; low and high end bracket the measured number.
By their numbers in this assay, from the lowest: compounds 4 and 3 (each within the scatter of the next); then compounds 1 and 2 (each within the scatter of the next).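

In this assay, removing the 2-phenylethenyl group does not by itself bring back the higher numbers: the exchange for the group of 5 heavy atoms gives a number 5 percentage points lower from compound 3 to compound 4 (within the scatter). Against the two compounds with smaller acyl amino groups, the same entering group gives a number 20 percentage points lower from compound 2 to compound 4 (beyond the scatter) and a number 20 percentage points lower from compound 1 to compound 4 (beyond the scatter), so this position can respond to more than the presence of 2-phenylethenyl, and the entering group, with no hydrogen-bond donor, does not match cyclopropyl or 2-chloropropyl on a carbonyl carbon here. Nothing measured explains why these numbers differ.

The compounds shown leave open whether losing the amide hydrogen matters or whether other features of the entering group account for the result. A free amino group on the same double-bonded ring carbon, or a longer alkyl chain on the carbonyl carbon, would help separate these possibilities.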